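This account rests on a few compounds, and the source may have more. Where it says the series, first, only, none or still open, it means among the compounds named here.

Series notes. The shared core carries a fluorine-substituted fused bicycle linked to an aminophenyl ring; compound 1 `N#Cc1cc(-c2nc3ccc(F)cc3s2)ccc1N` bears a nitrile on that ring, compound 2 `C[Si](C)(C)C#Cc1cc(-c2nc3ccc(F)cc3s2)ccc1N` a silicon-capped alkyne in the same position, and compound 3 `C#Cc1cc(-c2nc3ccc(F)cc3s2)ccc1N` the uncapped alkyne.

In a functional assay on MCF7 cells (Homo sapiens) for inhibition, with a stated time of 72 h (a lower number here means a stronger inhibitor of growth, a higher number a weaker inhibitor of growth), compound 1 gives 820 nM, and compound 2 gives 680 nM. Among the measured compounds shown here, the one measured step, a 1.2-fold lower number from compound 1 to compound 2 (0.08 log units; within the scatter), shows that exchanging the nitrile for the much larger silicon-bearing group leaves this assay essentially unchanged. Compound 2 therefore sits at one end of the two numbers only nominally: its gap to compound 1 is no more than repeat measurements would produce.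

The step to compound 3 is a hydrogen atom in place of a group of 4 heavy atoms (3 carbon, 1 silicon; no ring), on a triple-bonded carbon. For the measured compounds named here, no measured pair covers removal of a cap from an alkyne; the only bearing is indirect, from compound 1 to compound 2, where a change of this region and of larger size, a 1.2-fold lower number from compound 1 to compound 2 (0.08 log units; within the scatter), stayed within the scatter. Compound 3 is therefore expected to move no further than the scatter, a 1.1-fold higher number from compound 2 to compound 3 (0.05 log units; within the scatter), with a slight lean toward the nitrile figure of compound 1 because compound 1 gives 820 nM and the terminal alkyne is intermediate in size. Estimate for compound 3: 760 nM, range 350 nM to 1650 nM.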

Compound 3, concentration for 50% growth inhibition: 110 nM
Compound 3: middle estimate off by 6.9-fold (0.84 log units), on the high side; measured number outside the range, below it.
By their numbers in this assay, from the lowest: compound 3; then compounds 2 and 1 (each within the scatter of the next).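

Working notes on the position. In this assay, the substituent on this aromatic carbon does matter: removing the silicon-bearing cap gives the first separation in the series (a 6.2-fold lower number from compound 2 to compound 3 (0.79 log units; beyond the scatter)), and ethynyl in place of cyano gives a step of similar size (a 7.5-fold lower number from compound 1 to compound 3 (0.87 log units; beyond the scatter)). The alkyne alone does not account for this, as compound 2 also carries one yet stays within the scatter of compound 1, so the step depends on what sits on the triple-bonded carbon. Nothing available explains why the uncapped alkyne stands apart from the nitrile and the capped alkyne.

As far as these compounds go, it remains open whether a methyl or a hydroxymethyl group on the triple-bonded carbon would keep the number of compound 3 or return it to that of compound 2. From the compounds shown here alone, it is equally open whether a chlorine atom or an ethyl group on the aromatic carbon would match ethynyl.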